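Nitrophenyl isomer swap in the oxadiazole cytotoxicity series

The source may hold more compounds than are shown below. What is called first, only, known or untested is meant among the compounds shown, and "the series" means these compounds.

Compound 1 `CC(=O)OC[C@H]1O[C@H](OC[C@@H](Cn2cc(CN(c3nc(-c4cccc(C)c4)no3)C3CCCCC3)nn2)OC(C)=O)C=C[C@@H]1OC(C)=O` gives 46.4 ug/mL in an ADME assay on RAW264.7 cells (Mus musculus) for cytotoxicity, read by MTT assay, with a stated time of 48 h; on this read-out higher numbers stand for lower toxicity in this test and lower numbers for higher toxicity in this test.
Compound 2 `CC(=O)OC[C@H]1O[C@H](OC[C@@H](Cn2cc(CN(c3nc(-c4ccc([N+](=O)[O-])cc4)no3)C3CCCCC3)nn2)OC(C)=O)C=C[C@@H]1OC(C)=O` gives 64.1 ug/mL in this assay.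

Compound 2 has the highest of the two numbers in this assay, its nearest neighbour being compound 1, a 1.4-fold higher number from compound 1 to compound 2 (0.14 log units; within the scatter). Compound 3 `CC(=O)OC[C@H]1O[C@H](OC[C@@H](Cn2cc(CN(c3nc(-c4cccc([N+](=O)[O-])c4)no3)C3CCCCC3)nn2)OC(C)=O)C=C[C@@H]1OC(C)=O` differs from compound 2 by 3-nitrophenyl in place of 4-nitrophenyl on an aromatic carbon. For the measured compounds named here, the one measured step, a 1.4-fold higher number from compound 1 to compound 2 (0.14 log units; within the scatter), moved between two different aryl groups and stayed within the scatter; the present change keeps the same group and shifts only its position, so no step beyond the scatter is expected in this assay. For compound 3 the estimate is 60 ug/mL, range 35 ug/mL to 100 ug/mL, which means an expected step of a 1.1-fold lower number from compound 2 to compound 3 (0.03 log units; within the scatter).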

Compound 3, half-maximal cytotoxic concentration: 100 ug/mL
Beside the measured number, compound 3's estimate is 1.7-fold (0.22 log units) below it; the measured number falls inside the stated range.
By their numbers in this assay, from the lowest: compounds 1, 2 and 3 (each within the scatter of the next, the first and the last beyond it).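

In this assay, 3-nitrophenyl in place of 4-nitrophenyl, on the ring carbon between two ring nitrogen atoms, gives a 1.6-fold higher number from compound 2 to compound 3 (0.19 log units; within the scatter), so the two nitro isomers remain unseparated. Nitro in place of methyl on the same aryl ring gives the first step beyond the scatter in this set, though a modest one: a 2.2-fold higher number from compound 1 to compound 3 (0.33 log units; beyond the scatter). No measurement here bears on the reason for this step.

Still open, going by these compounds, is how an amine or a carboxylic acid in place of the nitro of 3-nitrophenyl would read in this assay.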